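The compounds below may be only part of what the source reports. "The series", "measured", "known", "first", "only" and "open" are said of these compounds alone.

Among the compounds with values here, compound 3 `Cn1ccc2c(Oc3ccc(NC(=O)c4nn(-c5ccc(Br)cc5F)ccc4=O)cc3F)ccnc21` is the one member of this small set that gives a number in a functional assay on A549 cells (Homo sapiens) for cytotoxicity, read by MTT assay, with a stated time of 72 h; a lower number here means a stronger inhibitor, a higher number a weaker inhibitor: it gives 26800 nM. Compound 1 `Cn1ccc2c(Oc3ccc(NC(=O)c4nn(-c5ccc(Cl)c(F)c5)ccc4=O)cc3)ccnc21` gives only a limit of the assay, > 60000 nM, in this assay. Compound 2 `COc1ccc(-n2ccc(=O)c(C(=O)Nc3ccc(Oc4ccnc5c4ccn5C)c(F)c3)n2)cc1` likewise gives only a limit, > 60000 nM, in this assay. Compounds 1 and 2 thus sit at the assay limit (the limit of > 60000 nM in this assay, at which 2 of the 3 values shown sit), and compound 3 stands alone with a measured value.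

Compound 4 `Cn1ccc2c(Oc3ccc(NC(=O)c4nn(-c5ccc(Cl)c(F)c5)ccc4=O)cc3F)ccnc21` differs from compound 3 in one place: 4-chloro-3-fluorophenyl in place of 4-bromo-2-fluorophenyl on an aromatic nitrogen. Within the data shown here, one measured step touches the same position, the exchange of the aryl group on the aromatic nitrogen, and it gave an at least 2.2-fold lower number from compound 2 to compound 3 (0.35 log units; beyond the scatter). That step went from a limit to a number, so its true size is not known. Compound 1 carries the same 4-chloro-3-fluorophenyl group as compound 4 and sits at the limit. From this, compound 4 is expected to show a step of a 1.7-fold higher number from compound 3 to compound 4 (0.23 log units; within the scatter) toward a weaker number in this assay, with a real chance of only a limit. The estimate for compound 4 in this assay is 45000 nM, within 15000 nM to 150000 nM.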

Compound 4, half-maximal inhibitory concentration: > 60000 nM
Compound 4 was reported as a limit (the forecaster's own chance of this, stated with the estimate: 45%); at least 1.3-fold (0.12 log units) between middle value and limit.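

With the rest of the molecule unchanged, the halogenated aryl group on the aromatic nitrogen proves sensitive to its exact form: in this assay, 4-chloro-3-fluorophenyl in place of 4-bromo-2-fluorophenyl gives an at least 2.2-fold higher number from compound 3 to compound 4 (0.35 log units; beyond the scatter). Carrying halogens is therefore not enough to give a measurable number, since compound 4 has both chlorine and fluorine on this ring and still reaches the assay limit, leaving compound 3 alone with a measured value: the limit of > 60000 nM in this assay, at which 3 of the 4 values shown sit. The steps to compound 4 from compound 1 and from compound 2 both join two limits and cannot be read.

This exchange alters both the halogen and where the fluorine sits, so the compounds shown cannot separate the two changes. They also leave open how an aryl group carrying an amine or a carboxylic acid would behave at this position.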